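Replacing a propargyl amide with an aryl amide

This account rests on a few compounds, and the source may have more. Where it says the series, first, only, none or still open, it means among the compounds named here.

Measured compounds:
compound 1, `C#CCNC(=O)c1ccc(C(CC)(CC)c2ccc(OCC(=O)C(C)(C)C)c(C)c2)n1CC`, 2200 nM
compound 2, `CCn1c(C(=O)NCCN(C)C)ccc1C(CC)(CC)c1ccc(OCC(O)C(C)(C)C)c(C)c1`, 14 nM

In an assay on HL-60 cells for agonist activity at vitamin D3 receptor (Homo sapiens), read by microscopy, with a stated time of 96 h (on this read-out lower numbers stand for an effect already at smaller amounts and higher numbers for an effect only at larger amounts of compound), compound 1 gives 2200 nM, the higher of the two numbers, while compound 2 gives 14 nM; the gap between them lies well beyond the usual scatter. The two differ in more than one place, so no single change can be read from that gap.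

Compound 3, `CCOc1ccc(NC(=O)c2ccc(C(CC)(CC)c3ccc(OCC(=O)C(C)(C)C)c(C)c3)n2CC)cc1`, keeps the core and side chain of compound 1 and changes only the amide nitrogen: 4-ethoxyphenyl in place of propargyl on an amide-type nitrogen. Among the compounds with values here, no measured pair shows what this change does on its own. Within the data shown here, with only the single neighbour value of compound 1 to lean on, the step of a 1.5-fold lower number from compound 1 to compound 3 (0.17 log units; within the scatter) is expected to be small, within the scatter or a slight move toward a lower number. Compound 3 is therefore estimated at 1500 nM, with a range from 300 nM to 7000 nM.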

Compound 3, half-maximal effective concentration: > 50000 nM
Compound 3: a limit, no number; the forecaster's own chance of this, stated with the estimate: 10%; middle value at least 33-fold (1.52 log units) from the limit.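

At this amide-type nitrogen, the choice of group weighs heavily: in this assay, putting 4-ethoxyphenyl in place of propargyl brings an at least 22-fold higher number from compound 1 to compound 3 (1.35 log units; beyond the scatter) and leaves the read-out without a measurable number. With the core and side chain unchanged, this nitrogen clearly does not accept every group alike: propargyl, with 3 heavy atoms, still gives a number, while 4-ethoxyphenyl, with 9 heavy atoms and an aromatic ring, does not. Compound 3 has only a limit of the assay, not a number: the limit of > 50000 nM in this assay, at which 1 of the 3 values shown sits.

The compounds shown leave open whether the loss goes with the aromatic ring itself or with the ethoxy group on it, which a plain phenyl or a benzyl on this nitrogen would help to separate. They also do not show how a carboxylic acid or a longer alkyl chain would behave here.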